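Trading a branched chain for a ring on the amine carbon

This account rests on a few compounds, and the source may have more. Where it says the series, first, only, none or still open, it means among the compounds named here.

Measured so far:
compound 1 `N[C@H](C(=O)Nc1cc2cc[nH]c(=O)c2cc1Cl)C1CCCCC1` 20 nM
compound 2 `CC(C)(C)C[C@@H](N)C(=O)Nc1cc2cc[nH]c(=O)c2cc1Cl` 110 nM
compound 3 `N[C@H]1CC[C@@H](C(=O)Nc2cc3cc[nH]c(=O)c3cc2Cl)CC1` 15 nM

In an assay on isolated protein for inhibition of Rho-associated protein kinase 2 (Homo sapiens) (a lower number here means a stronger inhibitor, a higher number a weaker inhibitor), compound 2 gives 110 nM, the highest of the three numbers; compound 1 lies a 7.3-fold lower number from compound 2 to compound 3 (0.87 log units; beyond the scatter) apart only in the case of compound 3, while compound 1 sits between them. From the compounds shown here alone, compound 4 `N[C@@H](C(=O)Nc1cc2cc[nH]c(=O)c2cc1Cl)C1CCCCC1` is untested. Against compound 2 it shows (cyclohexyl in place of neopentyl on a saturated chain carbon bound to an amine nitrogen and a carbonyl carbon). Going by the values given here, the one comparable step, a 7.3-fold lower number from compound 2 to compound 3 (0.87 log units; beyond the scatter), also replaced the branched chain with a ring and gave a clearly lower number, so a drop beyond the scatter is expected here too. Compound 1 carries the same cyclohexyl but a different spatial arrangement, and its value shows such a drop is plausible. For compound 4 the expected value is 60 nM, within 15 nM to 250 nM, an estimated 1.8-fold lower number from compound 2 to compound 4 (0.26 log units; within the scatter).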

Compound 4, half-maximal inhibitory concentration: 400 nM
For compound 4 the middle estimate is 6.7-fold (0.82 log units) below the measured one; measured number outside the range, above it.
By their numbers in this assay, from the lowest: compounds 3 and 1 (each within the scatter of the next); then compound 2; then compound 4.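

At this saturated chain carbon, spatial arrangement alone can move the number a long way: in this assay, inverting the stereocentre gives a 20-fold higher number from compound 1 to compound 4 (1.30 log units; beyond the scatter), and the cause is narrowed to a single feature: the fact that compounds 1 and 4 differ only in the configuration as drawn. A cyclohexyl ring at this carbon therefore does not by itself lower the number, since cyclohexyl in place of neopentyl gives a 3.6-fold higher number from compound 2 to compound 4 (0.56 log units; beyond the scatter). From the compounds shown here alone, it remains open whether inverting the stereocentre of compound 2 would shift its number as far, and whether a cyclopentyl or phenyl group at this carbon would come close to compound 1 at 20 nM.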